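Swapping cyclopentyl for 4-methylphenyl on the amide carbonyl

The source may report more compounds than this note shows. Statements on the series, on what has been measured and on what is new or still open speak of the compounds shown alone.

The measured compounds and their values in an assay (strain Wistar) for displacement of a labelled ligand from adenosine receptor A1 (Rattus norvegicus), read by scintillation counting; on this read-out higher numbers stand for weaker inhibition and lower numbers for stronger inhibition:
Compound 1, `O=C(Nc1nc(-c2ccccc2)nc2c1nnn2Cc1ccccc1)c1ccc(Cl)cc1`, 108 nM
Compound 2, `CCOc1ccccc1C(=O)Nc1nc(-c2ccccc2)nc2c1nnn2Cc1ccccc1`, 1850 nM
Compound 3, `O=C(Nc1nc(-c2ccccc2)nc2c1nnn2Cc1ccccc1)C1CCCC1`, 2.5 nM

In this assay compound 3 stands lowest of the three numbers. Its nearest neighbour is compound 1, a 43-fold lower number from compound 1 to compound 3 (1.64 log units; beyond the scatter); the furthest is compound 2, a 740-fold lower number from compound 2 to compound 3 (2.87 log units; beyond the scatter). Compound 4, `Cc1ccc(C(=O)Nc2nc(-c3ccccc3)nc3c2nnn3Cc2ccccc2)cc1`, has not yet been measured in this assay. The change from compound 3 to compound 4 is 4-methylphenyl in place of cyclopentyl on a carbonyl carbon.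

Among the measured compounds shown here, two measured steps bear on this change, both ending at the cyclopentyl amide. From compound 1 to compound 3, where cyclopentyl replaced 4-chlorophenyl on the carbonyl carbon, the step was a 43-fold lower number from compound 1 to compound 3 (1.64 log units; beyond the scatter). From compound 2 to compound 3, where cyclopentyl replaced 2-ethoxyphenyl, the step was a 740-fold lower number from compound 2 to compound 3 (2.87 log units; beyond the scatter). Compound 4 moves the other way, from cyclopentyl back to an aromatic six-membered ring, and 4-methylphenyl resembles the 4-chlorophenyl of compound 1 more closely than the 2-ethoxyphenyl of compound 2. A large step to a higher number is therefore expected. The expected step is a 40-fold higher number from compound 3 to compound 4 (1.60 log units; beyond the scatter), placing compound 4 near compound 1. The estimate for compound 4 in this assay is 100 nM, within a range from 30 nM to 400 nM.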

Compound 4, inhibition constant: 709 nM
For compound 4 the middle estimate is 7.1-fold (0.85 log units) below the measured one; the measured number lies above the stated range.
By their numbers in this assay, from the lowest: compound 3; then compound 1; then compound 4; then compound 2.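

In this assay, the new aromatic amide confirms the cyclopentyl preference at this position, with a 280-fold higher number from compound 3 to compound 4 (2.45 log units; beyond the scatter) making this the third aromatic ring on the carbonyl carbon to stand at a higher number than cyclopentyl, and none of the compounds shown goes against that pattern. The earlier compounds shown here could not show how much the group on an otherwise similar aromatic ring matters, but methyl in place of chloro gives a 6.6-fold higher number from compound 1 to compound 4 (0.82 log units; beyond the scatter), a modest step that lies beyond the scatter, so the 4-substituted aromatic amides are not interchangeable here. The aromatic series also stays ordered rather than collapsing to one level, since a 2.6-fold lower number from compound 2 to compound 4 (0.42 log units; beyond the scatter) leaves 4-methylphenyl between 4-chlorophenyl and 2-ethoxyphenyl, although this step also compares groups that differ in more than a single atom.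

With cyclopentyl the only non-aromatic group among these amides, the compounds shown leave open whether a cyclohexyl or cyclobutyl ring would keep its low number, and how an unsubstituted phenyl would stand against the methyl and chloro rings. No measurement offered here accounts for any of these differences.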